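The compounds below may be only part of what the source reports. "The series", "measured", "known", "first", "only" and "open" are said of these compounds alone.

Measured in an ADME assay on C8166 cells (Homo sapiens) for cytotoxicity, read by MTT assay; on this read-out lower numbers stand for higher toxicity in this test and higher numbers for lower toxicity in this test:
- compound 1 `Cc1cccc(-n2cc(C(=O)O)c(=O)c3c(O)c(Cc4cccc(Cl)c4F)ccc32)c1` gives 71600 nM
- compound 2 `Cc1ccc(-n2cc(C(=O)O)c(=O)c3c(O)c(Cc4cccc(Cl)c4F)ccc32)cc1C` gives 316000 nM
- compound 3 `O=C(O)c1cn(Cc2ccccc2)c2ccc(Cc3ccccc3F)c(O)c2c1=O` gives 156000 nM

Compound 2 has the highest number of the three, so it is the least toxic in this assay of this small set. Compound 3 lies nearest below it and compound 1 furthest below.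

The next compound to read is compound 4 `O=C(O)c1cn(Cc2ccccc2F)c2ccc(Cc3cccc(Cl)c3F)c(O)c2c1=O`. The change is 2-fluorobenzyl in place of 3,4-dimethylphenyl on an aromatic nitrogen.

Among the measured compounds shown here, only one measured step involves the group on this nitrogen: a 4.4-fold higher number from compound 1 to compound 2 (0.64 log units; beyond the scatter), for methyl in place of hydrogen on an aromatic carbon. So a small edit there has already moved the number by a modest amount. For the measured compounds named here, no measured step swaps the whole group. The nearest guide is compound 3, which also carries a benzyl group on this nitrogen and gives 156000 nM, though it differs from compound 4 elsewhere too. Compound 2 sits at the top of the set, so a modest fall is expected, with a wide margin.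

The estimate corresponds to a 2.4-fold lower number from compound 2 to compound 4 (0.39 log units; beyond the scatter), an expected step downward.

Compound 4 is expected at 130000 nM, with an estimated range of 45000 nM to 350000 nM.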

Compound 4, half-maximal cytotoxic concentration: 44900 nM
Compound 4: the middle estimate sits 2.9-fold (0.46 log units) above what was measured; measured number outside the range, below it.
By their numbers in this assay, from the lowest: compounds 4 and 1 (each within the scatter of the next); then compound 3; then compound 2.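

In this assay the whole group on the aromatic nitrogen can now be read as one swap, not only as a small edit on it: 2-fluorobenzyl in place of 3,4-dimethylphenyl gives a 7.0-fold lower number from compound 2 to compound 4 (0.85 log units; beyond the scatter) and this lies beyond the scatter, so the low toxicity of compound 2 does not carry over to this replacement. Set against 3-methylphenyl, the same 2-fluorobenzyl gives a 1.6-fold lower number from compound 1 to compound 4 (0.20 log units; within the scatter) and this lies within the scatter, so these two groups cannot be told apart at this position, and among the three compounds with this change compared, the 3,4-dimethylphenyl group of compound 2 alone stands clear. Nothing available on these compounds accounts for the size of either step.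

The step to compound 4 changes the aryl group for a benzyl group and brings in fluorine together, and the compounds shown do not separate these two parts of the change. Also open, from the compounds shown here alone, is whether a plain alkyl chain, or a longer chain ending in an amine, on this nitrogen would stay within the same span of numbers.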